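Calpain-2 inhibition: amide substituent series, next step

The source may report more compounds than this note shows. Statements on the series, on what has been measured and on what is new or still open speak of the compounds shown alone.

Within the data shown here, compound 2, `CCCCCCCCCCNC(=O)C(=O)C(CC)NC(=O)C(CC(C)C)NC(=O)OCc1ccccc1`, gives 600 nM in an assay on isolated protein (Oryctolagus cuniculus) for inhibition of Calpain-2 catalytic subunit (Homo sapiens), at pH 8.0 (on this read-out higher numbers stand for weaker inhibition and lower numbers for stronger inhibition), and stands highest of the two numbers so far. Compound 1, `CCC(NC(=O)C(CC(C)C)NC(=O)OCc1ccccc1)C(=O)C(=O)NCC(C)C`, gives 140 nM; the step of a 4.3-fold higher number from compound 1 to compound 2 (0.63 log units; beyond the scatter) is the only one measured, and it went beyond the scatter. Compound 3, `CCC(NC(=O)C(CC(C)C)NC(=O)OCc1ccccc1)C(=O)C(=O)NCc1ccccc1`, differs from compound 2 by phenyl in place of nonyl on a saturated chain carbon bound to an amide-type nitrogen. The benzyl group is closer in size to the isobutyl of compound 1 than to the decyl of compound 2, so the step of a 3.0-fold lower number from compound 2 to compound 3 (0.48 log units; beyond the scatter) is expected to run back toward the lower number, roughly reversing what was seen from compound 1 to compound 2. For compound 3 the expected value is 200 nM, within 60 nM to 700 nM.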

Compound 3, inhibition constant: 22 nM
Beside the measured number, compound 3's estimate is 9.1-fold (0.96 log units) above it; measured number outside the range, below it.
By their numbers in this assay, from the lowest: compound 3; then compound 1; then compound 2.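

Benzyl on the amide-type nitrogen outperforms both chains: decyl to benzyl gives a 27-fold lower number from compound 2 to compound 3 (1.44 log units; beyond the scatter), and the change from the isobutyl chain gives a 6.4-fold lower number from compound 1 to compound 3 (0.80 log units; beyond the scatter). Compound 3 therefore has the lowest number of the three, rather than falling between compound 1 and compound 2, so the aromatic ring does not behave here like a chain of intermediate length. Nothing available explains this gain.

As far as these compounds go, it remains open whether a phenethyl or pyridylmethyl group would hold this gain. From the compounds shown here alone, the effect of an amine or carboxylic acid on the benzyl ring is also open.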